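A methyl on the ring carbon of compound 3

The source may hold more compounds than are shown below. What is called first, only, known or untested is meant among the compounds shown, and "the series" means these compounds.

Of the compounds shown here, three have so far been measured in a functional assay on HCT-116 cells (Homo sapiens) for cytotoxicity, read by sulforhodamine B assay, with stated times of 4 h and 5 days; a lower number here means a stronger inhibitor, a higher number a weaker inhibitor. Compound 1 `O=[N+]([O-])c1nccn1CS(=O)(=O)NCCN1CCCC1` gives 11000 nM. Compound 2 `COCCNS(=O)(=O)CCn1cncc1[N+](=O)[O-]` gives 4400000 nM, and compound 3 `O=[N+]([O-])c1cncn1CCS(=O)(=O)NCCO` gives 5300000 nM. Compound 3 thus holds the highest of the three numbers; the step of a 1.2-fold higher number from compound 2 to compound 3 (0.08 log units; within the scatter) is within the scatter and comes from hydrogen in place of methyl on an oxygen on a saturated carbon, while compound 1 stands far lower than compound 3, beyond the scatter. The next compound, compound 4 `Cc1ncc([N+](=O)[O-])n1CCS(=O)(=O)NCCO`, differs from compound 3 by methyl in place of hydrogen on an aromatic carbon. Within the data shown here, none of the measured steps touches this position: the only single-point step, a 1.2-fold higher number from compound 2 to compound 3 (0.08 log units; within the scatter), concerns a methyl on an oxygen rather than on a ring carbon. Among the measured compounds shown here, compound 1 differs from the others in more than one place, so no step can be drawn from it. Nothing in the measured data therefore points to a shift beyond the scatter in this assay, in either direction. Compound 4 is expected to give 5300000 nM, with a range from 1500000 nM to 15000000 nM. That estimate means a step of no change at the digits printed from compound 3 to compound 4 (within the scatter), expected to lie within the scatter.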

Compound 4, half-maximal inhibitory concentration: 400000 nM
For compound 4 the middle estimate is 13-fold (1.12 log units) above the measured one; measured number outside the range, below it.
By their numbers in this assay, from the lowest: compound 1; then compound 4; then compounds 2 and 3 (each within the scatter of the next).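

In this assay, among these compounds, a methyl on the aromatic carbon between two ring nitrogen atoms gives a 13-fold lower number from compound 3 to compound 4 (1.12 log units; beyond the scatter), so this ring position, which no earlier step had touched, responds to the addition of a single carbon. Among the compounds shown here, the only earlier step, a 1.2-fold higher number from compound 2 to compound 3 (0.08 log units; within the scatter), concerned a methyl on an oxygen on a saturated carbon and stayed within the scatter; across these two steps, then, the methyl changes the number beyond the scatter only at the ring carbon. Nothing available here bears on the reason for this step.

The compounds shown leave open whether the step belongs to methyl alone, or whether an ethyl, a chlorine or an amine on the same ring carbon would move the number further, less or the other way. They also leave open whether the ring methyl would give a similar step with the methoxy end of compound 2, or with a carboxylic acid in place of the hydroxyl at the end of the side chain.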